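Chain Lengthening on the Carbamate of Pyrazoline Growth Inhibitors

The source may report more compounds than this note shows. Statements on the series, on what has been measured and on what is new or still open speak of the compounds shown alone.

Compound 1 `CCOC(=O)N1N=C(c2cccc(OC)c2)CC1c1cc(OC)c(OC)c(OC)c1`: 5820 nM
Compound 2 `CCCOC(=O)N1N=C(c2cccc(OC)c2)CC1c1cc(OC)c(OC)c(OC)c1`: > 10000 nM
Compound 3 `COC(=O)N1N=C(c2cccc(O)c2)CC1c1cc(OC)c(OC)c(OC)c1`: 650 nM

In a functional assay on HepG2 cells (Homo sapiens) for antiproliferative activity, read by MTT assay, with a stated time of 48 h (on this read-out higher numbers stand for weaker inhibition of growth and lower numbers for stronger inhibition of growth), compound 1 gives 5820 nM. Compound 2 gives > 10000 nM, which is a limit of this assay rather than a number (the limit of > 10000 nM in this assay, at which 1 of the 3 values shown sits). The change between them is methyl in place of hydrogen on a saturated chain carbon, two bonds along the chain from an oxygen next to a carbonyl group, and it made an at least 1.7-fold higher number from compound 1 to compound 2 (0.23 log units; that floor lies within the scatter). Compound 3 gives 650 nM in this assay; how its core differs from that of compound 1 is not broken down here. Compound 4 `CCOC(=O)N1N=C(c2cccc(O)c2)CC1c1cc(OC)c(OC)c(OC)c1` is not yet measured. It differs from compound 3 by methyl in place of hydrogen on a saturated chain carbon bound to an oxygen next to a carbonyl group. This is the same kind of change as that from compound 1 to compound 2, not the same: there the methyl entered two bonds along the chain from an oxygen next to a carbonyl group, here on a carbon bound to that oxygen. Compound 4 is expected to show a 2.3-fold higher number from compound 3 to compound 4 (0.36 log units; beyond the scatter), a weakening of similar size, resting on compound 1 and an at least 1.7-fold higher number from compound 1 to compound 2 (0.23 log units; that floor lies within the scatter). Compound 4 is therefore estimated at 1500 nM, between 600 nM and 4000 nM.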

Compound 4, concentration for 50% growth inhibition: 1790 nM
Beside the measured number, compound 4's estimate is 1.2-fold (0.08 log units) below it; the range from low to high includes it.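

In this assay, going from methoxycarbonyl to ethoxycarbonyl gives a 2.8-fold higher number from compound 3 to compound 4 (0.44 log units; beyond the scatter), while hydrogen in place of methyl on an oxygen on an aromatic ring gives a 3.3-fold lower number from compound 1 to compound 4 (0.51 log units; beyond the scatter). Adding a methyl to the carbamate chain raises the number on the core of compound 3, but a comparison with the other core cannot settle whether the size of the step stays the same: the same change on two cores in this assay, an at least 1.7-fold higher number (0.23 log units; that floor lies within the scatter) from compound 1 to compound 2 and a 2.8-fold higher number (0.44 log units; beyond the scatter) from compound 3 to compound 4; the limit leaves it open whether they differ Compound 2 gives > 10000 nM, which is a limit of the assay, so the true size of its step stays unknown.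

The compounds shown leave open how a longer chain, such as butoxycarbonyl, would read on either core. They also leave open what an amide in place of the carbamate would give.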